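A few compounds are considered here, and "the series" means these few. Any claim that something is new, unique, unknown or untested is made for them only; others in the source may bear on it.

Measured compounds:
compound 1 `COc1cc(-c2nn(-c3cccc(NC(=O)c4cccc(C(F)(F)F)c4)c3)cc2-c2ccncc2)ccc1Cl` — 811 nM
compound 2 `O=C(Nc1cccc(-n2cc(-c3ccncc3)c(-c3ccc(Cl)c(O)c3)n2)c1)Nc1cc(C(F)(F)F)cc(C(F)(F)F)c1` — 937 nM
compound 3 `O=C(Nc1cccc(-n2cc(-c3ccncc3)c(-c3ccc(Cl)c(O)c3)n2)c1)Nc1ccc(Cl)c(C(F)(F)F)c1` — 508 nM

In a functional assay on RXF 393 cells (Homo sapiens) for inhibition, read by sulforhodamine B assay, with a stated time of 48 h (on this read-out higher numbers stand for weaker inhibition of growth and lower numbers for stronger inhibition of growth), compound 1 gives 811 nM. Among the three numbers it stands second highest; compound 2 at 937 nM lies nearest, and compound 3 at 508 nM lies furthest, both within the scatter of the assay. The three values therefore sit close together, and no one of them can be called stronger or weaker than the others.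

Compound 4 `COc1cc(-c2nn(-c3cccc(NC(=O)Nc4ccc(Cl)c(Cl)c4)c3)cc2-c2ccncc2)ccc1Cl` has not yet been measured. Relative to compound 1 the change is (3,4-dichlorophenyl)amino in place of 3-(trifluoromethyl)phenyl on a carbonyl carbon, turning the amide linkage of compound 1 into a urea of the kind carried by compound 2 and compound 3. Within the data shown here, the only guide is that compound 2 and compound 3, both ureas, return values indistinguishable from that of compound 1, so the step from compound 1 to compound 4 is expected to be small, a 1.2-fold lower number from compound 1 to compound 4 (0.10 log units; within the scatter), with no direction beyond the scatter. Compound 4 is accordingly estimated at 650 nM, with a range from 250 nM to 1700 nM.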

Compound 4, concentration for 50% growth inhibition: 859 nM
Compound 4: middle estimate off by 1.3-fold (0.12 log units), on the low side; the measured number falls inside the stated range.
By their numbers in this assay, from the lowest: compounds 3, 1, 4 and 2 (each within the scatter of the next).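

In this assay, putting (3,4-dichlorophenyl)amino in place of 3-(trifluoromethyl)phenyl on a carbonyl carbon gives a 1.1-fold higher number from compound 1 to compound 4 (0.02 log units; within the scatter). Among these compounds, this is the first direct reading at this position, as compound 2 and compound 3 each differ from compound 1 in more than one place, and it shows that turning the amide into a urea, with its added hydrogen-bond donor, leaves the number within the scatter. Nothing available accounts for this outcome.

The step changes the linkage and the ring substituents together, so the contribution of each cannot be read from it, and the two could offset each other. From the compounds shown here alone, it also remains open whether a piperidine, a longer alkyl chain or a carboxylic acid on that carbonyl carbon would shift the number beyond the scatter.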